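Replacing the pendant ring of compound 1

A few compounds are considered here, and "the series" means these few. Any claim that something is new, unique, unknown or untested is made for them only; others in the source may bear on it.

Compound 1 `Cc1nc2c3ccccc3ccc2c2nc3c(ccc4ccccc43)c(-c3ccccc3S)c12`: 1420 nM
Compound 2 `Cc1nc2c3ccccc3ccc2c2nc3c(ccc4ccccc43)c(-c3nccnc3N)c12`: 3560 nM
Compound 3 `Cc1nc2c3ccccc3ccc2c2nc3c(ccc4ccccc43)c(-c3ccc(O)cc3)c12`: 3190 nM

In a functional assay on HCT-116 cells (Homo sapiens) for cytotoxicity, read by MTT assay, with a stated time of 48 h (a lower number here means a stronger inhibitor, a higher number a weaker inhibitor), compound 1 gives the lowest of the three numbers. The steps of a 2.5-fold higher number from compound 1 to compound 2 (0.40 log units; beyond the scatter) and a 2.2-fold higher number from compound 1 to compound 3 (0.35 log units; beyond the scatter) are both modest and beyond the scatter, whereas the values of compound 2 and compound 3 lie within the scatter of each other. Compound 4 `Cc1nc2c3ccccc3ccc2c2nc3c(ccc4ccccc43)c(-c3cccnc3)c12` differs from compound 1 in one place: pyridin-3-yl in place of 2-sulfanylphenyl on an aromatic carbon. Both measured steps from compound 1 bear on this change, since each replaces the 2-sulfanylphenyl group with another ring, and each raised the number modestly. A rise of similar size in this assay is therefore expected for compound 4. Compound 4 is expected to give about 3000 nM, within 1400 nM to 6500 nM. The expected step is a 2.1-fold higher number from compound 1 to compound 4 (0.32 log units; beyond the scatter).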

Compound 4, half-maximal inhibitory concentration: 34200 nM
Compound 4: the middle estimate sits 11-fold (1.06 log units) below what was measured; the whole stated range lies below it.
By their numbers in this assay, from the lowest: compound 1; then compounds 3 and 2 (each within the scatter of the next); then compound 4.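

Placing pyridin-3-yl at this position gave a 24-fold higher number from compound 1 to compound 4 (1.38 log units; beyond the scatter), along with an 11-fold higher number from compound 3 to compound 4 (1.03 log units; beyond the scatter) and a 9.6-fold higher number from compound 2 to compound 4 (0.98 log units; beyond the scatter), so the position separates pendant rings far more sharply than the earlier compounds showed. Compound 4 is also the only one of the four whose pendant ring carries no substituent, while the others bear a sulfanyl, amino or hydroxyl group. Nothing available explains this jump. The compounds shown leave open whether the ring nitrogen or the missing substituent matters more. Plain phenyl and an amine on pyridin-3-yl would separate these two changes.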